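The source may hold more compounds than are shown below. What is called first, only, known or untested is meant among the compounds shown, and "the series" means these compounds.

Measured compounds and their values:

compound 1 `O=C1/C(=C/c2ccccc2)CCC/C1=C\c1cccc([N+](=O)[O-])c1`: 5.06
compound 2 `O=C1/C(=C/c2ccccc2)CCC/C1=C\c1ccc([N+](=O)[O-])cc1`: 5.08
compound 3 `COc1ccc(/C=C2\CCC/C(=C\c3cccc([N+](=O)[O-])c3)C2=O)cc1`: 5.06

Of the compounds shown here, three of this study have been measured in a physicochemical assay for lipophilicity (on this read-out lower numbers stand for lower lipophilicity and higher numbers for higher lipophilicity), and a fourth, compound 4 `COc1ccc(/C=C2\CCC/C(=C\c3ccc([N+](=O)[O-])cc3)C2=O)cc1`, is still to be measured in this assay.

Compound 1 and compound 3 differ in one place, (methoxy in place of hydrogen on an aromatic carbon). In this assay this gave no change at the digits printed from compound 1 to compound 3 (within the scatter). Compound 2 is built on a different core from compound 1; the two have the same atoms joined differently, and the difference between the two cores is not broken down here. In this assay compound 2 gives 5.08, and compound 1 gives 5.06, two numbers that sit within the usual scatter of each other, so nothing can be said about an order between them.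

Going by the values given here, compound 4 stands to compound 2 as compound 3 stands to compound 1: the change is methoxy in place of hydrogen on an aromatic carbon, the same change, made in the same place on the ring, as the one from compound 1 to compound 3. The step from compound 2 to compound 4 in this assay is therefore expected to be small, no change at the digits printed from compound 2 to compound 4 (within the scatter), and this rests on the measured pair, because no change at the digits printed from compound 1 to compound 3 (within the scatter). For compound 4 the value in this assay is estimated at 5.08, with an expected range from 4.8 to 5.4.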

Compound 4, partition coefficient: 5.08
The estimate for compound 4 equals the measured number at the digits printed; the measured number falls inside the stated range.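

Moved onto the core of compound 2, methoxy in place of hydrogen on an aromatic carbon gave the same outcome in this assay as it had on the core of compound 1: the new step reads no change at the digits printed from compound 2 to compound 4 (within the scatter), and the earlier one reads no change at the digits printed from compound 1 to compound 3 (within the scatter). Going by these compounds alone, this shows that, across these two cores with the same atoms joined differently, the change carried over as a step too small to separate from the scatter, but it rests on only two pairs, and two steps of this kind cannot show that a larger step would carry over in the same way, or that the result would hold on any third core. Nothing given here accounts for why the two steps agree, so the agreement stands as an observation and no more.

The compounds shown leave open how an amine, a carboxylic acid or a longer chain such as butoxy would read in this assay at the place on the ring taken by methoxy. They also leave open whether any of these groups would give the same step on both cores, as methoxy does here.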